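The compounds below may be only part of what the source reports. "The series", "measured", "known", "first", "only" and "open" are said of these compounds alone.

Measured in a functional assay on HepG2 cells (Homo sapiens) for antiproliferative activity, read by MTT assay, with a stated time of 72 h; a higher number here means a weaker inhibitor, a lower number a stronger inhibitor:
Compound 1 `O=C1O/C(=C\Cn2cnc3c(F)nc(F)c(Cl)c32)C(OCc2ccccc2)=C1OCc1ccccc1`: > 100000 nM, a limit.
Compound 2 `O=C1O/C(=C\Cn2cnc3cc[nH]c3c2=O)C(OCc2ccccc2)=C1OCc1ccccc1`: > 100000 nM, a limit.

Compound 2 therefore stands at no readable number, and the same holds for compound 1. Compound 3 `O=C1O/C(=C\Cn2cnc3cncc(Br)c32)C(OCc2ccccc2)=C1OCc1ccccc1` differs from compound 2 in one place: a group of 10 heavy atoms (6 carbon, 3 nitrogen, 1 bromine; one five-membered aromatic ring with 2 hetero atoms, one six-membered aromatic ring with 1 hetero atom) in place of a group of 10 heavy atoms (6 carbon, 3 nitrogen, 1 oxygen; one five-membered aromatic ring with 1 hetero atom, one six-membered aromatic ring with 2 hetero atoms), on a saturated chain carbon bound to a double-bonded chain carbon. Going by the values given here, the only measured step that bears on this change is a step that the two limits leave unreadable from compound 1 to compound 2, which has no readable size, and the data show (the limit of > 100000 nM in this assay, at which 2 of the 2 values shown sit). No step beyond the scatter is expected, so the expected change is a number no higher from compound 2 to compound 3 (the limit leaves the size open), and a further limit is likely. Compound 3 is estimated at 100000 nM, with an expected range from 40000 nM to 150000 nM.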

Compound 3, half-maximal inhibitory concentration: 46900 nM
The estimate for compound 3 lay 2.1-fold (0.33 log units) above the measured number, within the range that was stated.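

In this assay, the group on a saturated chain carbon bound to a double-bonded chain carbon can shift the read-out, as the bromine-bearing group gives an at least 2.1-fold lower number from compound 2 to compound 3 (0.32 log units; beyond the scatter). Set against the fluorine- and chlorine-bearing group, it gives an at least 2.1-fold lower number from compound 1 to compound 3 (0.32 log units; beyond the scatter). Compound 3 is the first compound here with a readable number, while both steps keep an open size, with compound 1 and compound 2 each resting on a limit: the limit of > 100000 nM in this assay, at which 2 of the 3 values shown sit.

The step between compound 1 and compound 2 cannot be read, and in the step to compound 3 the bromine and the ring pattern change together, so neither can be credited alone. From the compounds shown here alone, whether an amine in place of the bromine would keep this number also stays open.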